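This account rests on a few compounds, and the source may have more. Where it says the series, first, only, none or still open, it means among the compounds named here.

Working notes on the series. Compound 1 `COc1cccc(COc2ccc3cc(C(=O)/C=C/c4ccc(Cl)cc4Cl)c(=O)oc3c2)c1` has no result: in a functional assay on MOLT-4 cells (Homo sapiens) for cytotoxicity, read by MTT assay, with a stated time of 72 h (on this read-out higher numbers stand for weaker inhibition and lower numbers for stronger inhibition), compound 1 gives "not determined" (no result reported), so nothing places it on the scale. Going by the values given here, compound 2 `COc1cc(/C=C/C(=O)c2cc3cc(OCc4ccccc4)ccc3oc2=O)cc(OC)c1OC` is the only member with a number, and in this assay compound 2 gives 10300 nM, which is weak inhibition on this read-out. Compound 3 `COc1cccc(COc2ccc3cc(C(=O)/C=C/c4cccc(OC)c4OC)c(=O)oc3c2)c1` is not yet measured. It differs from compound 1 by 2,3-dimethoxyphenyl in place of 2,4-dichlorophenyl on a double-bonded chain carbon bound to a double-bonded chain carbon. Among the compounds with values here, no measured pair shares this change, and compound 1 lacks a value, so the size of the step from compound 1 to compound 3 in this assay cannot be read from the data; compound 2 differs from both in more than one place and gives no direct anchor for this change. The expectation is therefore a step within the usual scatter, with no direction assigned. Compound 3 is expected to give about 10000 nM in this assay, with a range from 3000 nM to 40000 nM. The only support for this is the reading of compound 2 at 10300 nM, which sets the level the shared core has shown so far.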

Compound 3, half-maximal inhibitory concentration: 22800 nM
Beside the measured number, compound 3's estimate is 2.3-fold (0.36 log units) below it; measured number inside the range.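

In this assay compound 1 gives "not determined" (no result reported) and compound 2 differs from compound 3 in more than one place, so no step can be read from these compounds. The compounds shown leave open what 2,3-dimethoxyphenyl in place of 2,4-dichlorophenyl does to the read-out. No supporting evidence bears on this result.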